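From Fluoro to (Trifluoromethyl)sulfanyl on an Aromatic Carbon

This account rests on a few compounds, and the source may have more. Where it says the series, first, only, none or still open, it means among the compounds named here.

In a functional assay on CCRF-CEM cells (Homo sapiens) for inhibition, read by MTT assay, with a stated time of 72 h (a higher number here means a weaker inhibitor, a lower number a stronger inhibitor), compound 1 `COc1cccc(/C=C/C(=O)Nc2cc(OC)c(OC)c(OC)c2)c1` gives 23400 nM and compound 2 `COc1cc(NC(=O)/C=C/c2cccc(OCc3ccccc3)c2)cc(OC)c1OC` gives 17300 nM while compound 3 `C=C(Br)C(=O)Nc1cccc(/C=C/C(=O)Nc2ccc(F)cc2)c1` gives 16600 nM and so stands level with both within the scatter. Compound 4 `C=C(Br)C(=O)Nc1cccc(/C=C/C(=O)Nc2ccc(SC(F)(F)F)cc2)c1` carries (trifluoromethyl)sulfanyl in place of fluoro on an aromatic carbon, para to a large group, a change counted as (trifluoromethyl)sulfanyl in place of fluoro on an aromatic carbon and not matched by any measured step. The nearest guide lies elsewhere, on the core of compound 1, where phenyl in place of hydrogen gave a 1.4-fold lower number from compound 1 to compound 2 (0.13 log units; within the scatter) and stayed within the scatter. A modest move toward a lower number in this assay is therefore expected, with a 1.4-fold lower number from compound 3 to compound 4 (0.14 log units; within the scatter) as the estimated step and nothing beyond the scatter foreseen. Compound 4 is estimated at 12000 nM with a range from 4000 nM to 25000 nM in this read-out.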

Compound 4, half-maximal inhibitory concentration: 15300 nM
The estimate for compound 4 lay 1.3-fold (0.11 log units) below the measured number, and the stated range covers the measured number.
By their numbers in this assay, from the lowest: compounds 4, 3, 2 and 1 (each within the scatter of the next).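

In this assay, going by these compounds alone, the first measured change at this position, (trifluoromethyl)sulfanyl in place of fluoro on an aromatic carbon, gave a 1.1-fold lower number from compound 3 to compound 4 (0.04 log units; within the scatter) and so stayed within the scatter. The position, para to a large group, therefore took a group of more heavy atoms, including sulfur, without a change in the number that could be told from the scatter. Nothing at hand accounts for this outcome. Still open, on these data alone, is whether an amine or a carboxylic acid at this place would shift the number beyond the scatter.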